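The source may hold more compounds than are shown below. What is called first, only, known or untested is meant among the compounds shown, and "the series" means these compounds.

Measured so far in an assay on isolated protein (Mus musculus) for inhibition of IL15-IL15 receptor (Homo sapiens), read by resazurin assay, with stated times of 30 min and 2.5 days; on this read-out lower numbers stand for stronger inhibition and higher numbers for weaker inhibition: compound 1 `Cn1c(Cc2nn(C)c(=O)c3ccccc23)nnc1SCCCCCCCC(=O)Nc1ccc(Cl)cc1`, 800 nM; compound 2 `COc1ccc(NC(=O)CCCCCCCSc2nnc(Cc3nn(C)c(=O)c4ccccc34)n2C)cc1`, 3900 nM; compound 3 `CC(C)COc1ccc(NC(=O)CCCCCCCSc2nnc(Cc3nn(C)c(=O)c4ccccc34)n2C)cc1`, 4800 nM.

Compound 3 holds the highest number of the three; it lies within the scatter of compound 2 and is separated from compound 1 by a 6.0-fold higher number from compound 1 to compound 3 (0.78 log units; beyond the scatter). Compound 4 `Cn1c(Cc2nn(C)c(=O)c3ccccc23)nnc1SCCCCCCCC(=O)Oc1ccc(Cl)cc1Cl` differs from compound 3 by 2,4-dichlorophenoxy in place of (4-(isobutoxy)phenyl)amino on a carbonyl carbon. For the measured compounds named here, the steps that bear on this are a 6.0-fold higher number from compound 1 to compound 3 (0.78 log units; beyond the scatter) and a 4.9-fold higher number from compound 1 to compound 2 (0.69 log units; beyond the scatter), both giving a lower number for chloro on the aromatic ring than for an alkoxy group. Going by the values given here, no measured step covers the amide replaced by an ester, so that part of the change is unsupported and widens the range. Compound 4 is therefore expected to give a lower number, a 3.2-fold lower number from compound 3 to compound 4 (0.51 log units; beyond the scatter), estimated at 1500 nM with a range of 400 nM to 6000 nM.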

Compound 4, half-maximal inhibitory concentration: 800 nM
The estimate for compound 4 lay 1.9-fold (0.27 log units) above the measured number, within the range that was stated.
By their numbers in this assay, from the lowest: compounds 1 and 4 (each within the scatter of the next); then compounds 2 and 3 (each within the scatter of the next).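

The amide nitrogen on the carbonyl carbon is not needed to keep this level of inhibition: 2,4-dichlorophenoxy in place of (4-chlorophenyl)amino gives no change at the digits printed from compound 1 to compound 4 (within the scatter) and stays level with the anilide. The same dichlorinated ester also stands apart from both alkoxy anilides, with a 6.0-fold lower number from compound 3 to compound 4 (0.78 log units; beyond the scatter) and a 4.9-fold lower number from compound 2 to compound 4 (0.69 log units; beyond the scatter) beyond the scatter. Nothing available accounts for these steps.

The ester linkage and the second chloro change together, so neither effect can be read alone. Going by these compounds, a 4-chlorophenyl ester or a 2,4-dichlorophenyl amide would separate them, and a carboxylic acid on the ring remains open.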